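A vinyl group added to a compound at the limit

The source may report more compounds than this note shows. Statements on the series, on what has been measured and on what is new or still open speak of the compounds shown alone.

compound 1 `CN(c1ccncc1)n1cccc1`: > 20 mg/kg
compound 2 `CCCCN(c1ccncc1)n1cccc1`: > 20 mg/kg

In a functional assay on the whole organism with Mus musculus as the target (on this read-out higher numbers stand for an effect only at larger amounts of compound and lower numbers for an effect already at smaller amounts), compound 1 gives > 20 mg/kg as a limit of the assay, not a number. Compound 2 gives > 20 mg/kg as a limit too. The whole picture so far is the limit of > 20 mg/kg in this assay, at which 2 of the 2 values shown sit, and nothing firmer. Among the measured compounds shown here, the one measured step is a step that the two limits leave unreadable from compound 1 to compound 2 and it has no size to carry over.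

Compound 3 `C=Cc1cccn1N(C)c1ccncc1` differs from compound 1 by vinyl in place of hydrogen on an aromatic carbon in a single place: vinyl in place of hydrogen on an aromatic carbon. With no readable step behind it, no change beyond the usual scatter is expected in either direction in this assay and compound 3 may well stop at the same limit. The expected change is a step that the limit leaves unreadable from compound 1 to compound 3 and remains a rough estimate. For compound 3 the estimated value is 30 mg/kg within an expected range of 10 mg/kg to 90 mg/kg on this thin evidence.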

Compound 3, dose for half-maximal effect: 8.3 mg/kg
Estimate against measurement, compound 3: 3.6-fold (0.56 log units) above, and the stated range ends above it.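

In this assay, vinyl on this aromatic carbon, next to the ring nitrogen, gives an at least 2.4-fold lower number from compound 1 to compound 3 (0.38 log units; beyond the scatter), so a change at this place on the five-membered aromatic ring can bring a measurable effect at a dose that can be given a number. The full size of this step cannot be read, as its starting point is a limit and not a number: the limit of > 20 mg/kg in this assay, at which 2 of the 3 values shown sit. The step from compound 1 to compound 2 cannot be read, which leaves this as the only change shown with a readable direction.

On these data alone, whether an ethyl group, which has no double bond, or an amine on the same aromatic carbon would lower the number as well remains open. As far as these compounds go, it is also open whether vinyl elsewhere on that ring would do the same.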